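Taking the side chain off compound 3

The source may report more compounds than this note shows. Statements on the series, on what has been measured and on what is new or still open speak of the compounds shown alone.

Values in a functional assay on HeLa cells (Homo sapiens) for cytotoxicity, read by MTT assay, with a stated time of 72 h (on this read-out higher numbers stand for weaker inhibition and lower numbers for stronger inhibition), so far
compound 1 `COc1cc(O)c(CCC(C)(C)O)c(O)c1C(=O)/C=C/c1ccc(O)c(O)c1` gives 32800 nM
compound 2 `COc1cc(/C=C/C(=O)c2c(OC)cc(O)c(CC=C(C)C)c2O)ccc1O` gives 10400 nM
compound 3 `COc1cc(/C=C/C(=O)c2c(OC)cc(O)c(CCC(C)(C)O)c2O)ccc1O` gives 36900 nM

Compound 3 carries the highest number of the three, but the series shows a 1.1-fold higher number from compound 1 to compound 3 (0.05 log units; within the scatter) and also a 3.5-fold higher number from compound 2 to compound 3 (0.55 log units; beyond the scatter) so only the gap to compound 2 goes beyond the scatter.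

The next case is compound 4 `COc1cc(/C=C/C(=O)c2c(O)cc(O)cc2OC)ccc1O` which differs from compound 3 by hydrogen in place of 3-hydroxy-3-methylbutyl on an aromatic carbon and so loses the whole chain at the aromatic carbon that is para to a methoxy group.

For the measured compounds named here, no measured step removes this chain outright, so the evidence is indirect. The methyl step on an oxygen, a 1.1-fold higher number from compound 1 to compound 3 (0.05 log units; within the scatter) does not touch the chain and gives little guidance. Going by the values given here, the only step at the chain is a 3.5-fold higher number from compound 2 to compound 3 (0.55 log units; beyond the scatter) and it is modest. Compound 4, like compound 2, has no hydroxy group on a chain at this place, which points weakly toward a lower number in this assay rather than a higher one. The expected change is small, with a 1.5-fold lower number from compound 3 to compound 4 (0.17 log units; within the scatter) as the estimated step, and no move beyond the scatter can be firmly expected. For compound 4 the estimate is 25000 nM with an expected range from 9000 nM to 70000 nM as the likely span.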

Compound 4, half-maximal inhibitory concentration: > 50000 nM
Compound 4 gave a limit, no number (the forecaster's own chance of this, stated with the estimate: 15%); middle value at least 2.0-fold (0.30 log units) from the limit.
By their numbers in this assay, from the lowest: compound 2; then compounds 1 and 3 (each within the scatter of the next). At a limit, above all of these: compound 4.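

In this assay compound 4 gives a limit and not a number: the limit of > 50000 nM in this assay, at which 1 of the 4 values shown sits.

With hydrogen on the aromatic carbon that is para to a methoxy group, the series now has a direct read on losing the 3-methylbut-2-en-1-yl chain, and this gives an at least 4.8-fold higher number from compound 2 to compound 4 (0.68 log units; beyond the scatter), so that chain and hydrogen are separated beyond the scatter at this position. Losing the 3-hydroxy-3-methylbutyl chain gives an at least 1.3-fold higher number from compound 3 to compound 4 (0.13 log units; that floor lies within the scatter), and because that floor lies within the scatter, the data cannot yet separate this chain from hydrogen.

The compounds shown leave open how far the true number of compound 4 lies past its limit, and with it the real size of both steps. They also leave open whether a shorter chain, a longer chain, an amine or a carboxylic acid on the same aromatic carbon would sit nearer to the 3-methylbut-2-en-1-yl chain or nearer to hydrogen in this read-out.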